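The source may hold more compounds than are shown below. What is called first, only, known or untested is meant among the compounds shown, and "the series" means these compounds.

Compound 1 `Nc1cccc2c(-c3cccc(NC(=O)c4ccc5c(c4)OCCO5)c3)ccnc12` is the reference point: in a functional assay on SK-MEL-28 cells (Homo sapiens) for antiproliferative activity, read by sulforhodamine B assay, with a stated time of 48 h (on this read-out lower numbers stand for stronger inhibition and higher numbers for weaker inhibition), compound 1 gives 85 nM. Compound 2 `CC(=O)Nc1cccc2c(-c3cccc(NC(=O)c4ccc5c(c4)OCCO5)c3)ccnc12` carries the change (acetyl in place of hydrogen on a nitrogen on an aromatic ring). The value of compound 2 in this assay is a limit rather than a number, > 20000 nM. The step of an at least 230-fold higher number from compound 1 to compound 2 (2.37 log units; beyond the scatter) is therefore only bounded from one side, because of the limit of > 20000 nM in this assay, at which 1 of the 3 values shown sits. Compound 3 `Nc1cccc2c(-c3cccc(NC(=O)Nc4cc(C(F)(F)F)cc(C(F)(F)F)c4)c3)ccnc12` gives 2100 nM in this assay; the difference between the core of compound 1 and the core of compound 3 is not broken down here. Compound 4 `CC(=O)Nc1cccc2c(-c3cccc(NC(=O)Nc4cc(C(F)(F)F)cc(C(F)(F)F)c4)c3)ccnc12` is related to compound 3 by the same change, (acetyl in place of hydrogen on a nitrogen on an aromatic ring). Compound 4 is expected to show the step of a 14-fold higher number from compound 3 to compound 4 (1.15 log units; beyond the scatter), resting on the size of an at least 230-fold higher number from compound 1 to compound 2 (2.37 log units; beyond the scatter) seen once so far. Compound 4 is accordingly estimated at 30000 nM, most likely reported as a limit.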

Compound 4, half-maximal inhibitory concentration: 23400 nM
Compound 4: middle estimate off by 1.3-fold (0.11 log units), on the high side; the measured number falls inside the stated range.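

In this assay, acetyl in place of hydrogen on a nitrogen on an aromatic ring again goes with weaker inhibition, with an 11-fold higher number from compound 3 to compound 4 (1.05 log units; beyond the scatter). The direction repeats on the two cores shown, but the size of the step does not carry over from one to the other: the same change on two cores in this assay, an at least 230-fold higher number (2.37 log units; beyond the scatter) from compound 1 to compound 2 and an 11-fold higher number (1.05 log units; beyond the scatter) from compound 3 to compound 4, at least 21-fold (1.32 log units) apart, beyond the scatter of two such steps. On these data alone, the value of compound 2, > 20000 nM, is a limit and not a number, so the full size of the gap between the steps stays unknown: the limit of > 20000 nM in this assay, at which 1 of the 4 values shown sits.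

The compounds shown leave open whether a methyl or a propanoyl group on that nitrogen would give a similar step. Also open, as far as these compounds go, is how the change behaves on a third core, for instance one with a carboxylic acid in place of the trifluoromethyl groups.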